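Halogen swap on a fused ring, second occurrence

This account rests on a few compounds, and the source may have more. Where it says the series, first, only, none or still open, it means among the compounds named here.

Compound 1 `COc1ccc(C2=NN(C3=NC(=O)/C(=C4\C(=O)Nc5ccc(Br)cc54)S3)C(c3ccc(OC)cc3)C2)cc1` gives 200 nM in a functional assay on cells (Cancer cell lines, Homo sapiens) for cytotoxicity, read by sulforhodamine B assay, with a stated time of 48 h; on this read-out higher numbers stand for weaker inhibition of growth and lower numbers for stronger inhibition of growth. Compound 2 `COc1ccc(C2=NN(C3=NC(=O)/C(=C4\C(=O)Nc5ccc(Cl)cc54)S3)C(c3ccc(OC)cc3)C2)cc1` gives 210 nM in this assay, and the step of a 1.1-fold higher number from compound 1 to compound 2 (0.02 log units; within the scatter) corresponds to the change (chloro in place of bromo on an aromatic carbon). Compound 3 `COc1ccc(C2=NN(C3=NC(=O)/C(=C4\C(=O)Nc5ccc(Br)cc54)S3)C(c3ccc(Cl)cc3)C2)cc1` gives 130 nM in this assay; it differs from compound 1 by chloro in place of methoxy on an aromatic carbon, with the step of a 1.5-fold lower number from compound 1 to compound 3 (0.19 log units; within the scatter). Compound 4 `COc1ccc(C2=NN(C3=NC(=O)/C(=C4\C(=O)Nc5ccc(Cl)cc54)S3)C(c3ccc(Cl)cc3)C2)cc1` has not yet been measured in this assay. It differs from compound 3 by chloro in place of bromo on an aromatic carbon, which is the same change already seen from compound 1 to compound 2, made here on the core of compound 3 rather than the core of compound 1; the two cores differ by chloro in place of methoxy on an aromatic carbon. Since the earlier occurrence a 1.1-fold higher number from compound 1 to compound 2 (0.02 log units; within the scatter) stayed within the scatter, the step expected from compound 3 to compound 4 is estimated at a 1.1-fold higher number from compound 3 to compound 4 (0.03 log units; within the scatter), resting on that single precedent. Compound 4 is therefore expected to give about 140 nM in this assay, with an estimated range from 80 nM to 250 nM, because compound 3 gives 130 nM.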

Compound 4, concentration for 50% growth inhibition: 210 nM
For compound 4 the middle estimate is 1.5-fold (0.18 log units) below the measured one, and the stated range covers the measured number.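

In this assay, chloro in place of bromo gives a 1.6-fold higher number from compound 3 to compound 4 (0.21 log units; within the scatter), and this step agrees with its earlier occurrence on the other core: the same change on two cores in this assay, a 1.1-fold higher number (0.02 log units; within the scatter) from compound 1 to compound 2 and a 1.6-fold higher number (0.21 log units; within the scatter) from compound 3 to compound 4, 1.5-fold (0.19 log units) apart, within the scatter of two such steps. Chloro in place of methoxy, now on the core of compound 2, gives no change at the digits printed from compound 2 to compound 4 (within the scatter), and this step also agrees with its earlier occurrence: the same change on two cores in this assay, a 1.5-fold lower number (0.19 log units; within the scatter) from compound 1 to compound 3 and no change at the digits printed (within the scatter) from compound 2 to compound 4, 1.5-fold (0.19 log units) apart, within the scatter of two such steps. Across these four compounds, each change therefore carries from one core to the other without a difference beyond the scatter, but every step also lies within the scatter, so this does not show that either change has an effect of its own or that the agreement would hold on other cores.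

The compounds shown carry only bromo or chloro at one varied place and only methoxy or chloro at the other. Going by these compounds, whether an amine, a carboxylic acid or a nitrile at either place would give a step beyond the scatter remains open.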